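The source may report more compounds than this note shows. Statements on the series, on what has been measured and on what is new or still open speak of the compounds shown alone.

Measured so far:
Compound 1 `O=C(OCc1ccccc1)SCCCCCCNC(=O)c1cc(-c2ccncc2)n[nH]1`: 19700 nM
Compound 2 `CC(C)C(=O)SCCCCCCNC(=O)c1cc(-c2ccncc2)n[nH]1`: > 50000 nM
Compound 3 `CCCCCCCC/C=C\CCCCCCCC(=O)SCCCCCCNC(=O)c1cc(-c2ccncc2)n[nH]1`: > 50000 nM

For the measured compounds named here, in an ADME assay on HEK293 cells (Homo sapiens) for inhibition, read by MTT assay, with a stated time of 96 h (a lower number here means a stronger inhibitor of growth, a higher number a weaker inhibitor of growth), compound 1 gives 19700 nM, the only actual number among the three. For compound 2, > 50000 nM is a limit of the assay. For compound 3, > 50000 nM is likewise a limit. Only compound 1 stands clear of the limit of > 50000 nM in this assay, at which 2 of the 3 values shown sit.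

Compound 4 `CCC(=O)SCCCCCCNC(=O)c1cc(-c2ccncc2)n[nH]1` has not yet been measured. It differs from compound 1 as follows: ethyl in place of benzyloxy on a carbonyl carbon. Going by the values given here, the closest measured change is the one to compound 2, with isopropyl in place of benzyloxy on a carbonyl carbon, and it gives an at least 2.5-fold higher number from compound 1 to compound 2 (0.40 log units; beyond the scatter). On these data alone, that step lies beyond the scatter, but it ends at a limit, so its full size is unknown.

A step of similar size and direction, towards a higher number in this assay, is therefore expected here. The expected step is a 2.5-fold higher number from compound 1 to compound 4 (0.40 log units; beyond the scatter). The estimated value for compound 4 is 50000 nM, with an expected range of 25000 nM to 100000 nM.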

Compound 4, concentration for 50% growth inhibition: > 50000 nM
Compound 4: no number, only a limit; the forecaster's own chance of this, stated with the estimate: 70%; the middle value lies on the limit itself.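

In this assay, ethyl in place of benzyloxy on the carbonyl carbon gives an at least 2.5-fold higher number from compound 1 to compound 4 (0.40 log units; beyond the scatter), so a second small group at this place, after the isopropyl of compound 2, also ends without a number. Compound 2 and compound 4 both stand at a limit, and the step between them cannot be read, so nothing can be said about the effect of the extra methyl. Compound 1, with benzyloxy, remains the only compound shown with an actual number, and the others share one ceiling: the limit of > 50000 nM in this assay, at which 3 of the 4 values shown sit.

The compounds shown leave open whether the difference rests on the oxygen or on the six-membered aromatic ring of benzyloxy, which a phenyl group or an ethoxy group on the carbonyl carbon could separate. On these data alone, how far compound 2 and compound 4 lie beyond the limit also remains unknown.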